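The compounds below may be only part of what the source reports. "The series", "measured", "known", "first", "only" and "open" are said of these compounds alone.

Compound 1 `O=C(/C=C/c1ccc(N2CCCCC2)cc1)c1ccsc1`: in an ADME assay on PBMC cells (Homo sapiens) for cytotoxicity, with a stated time of 5 days (on this read-out lower numbers stand for stronger inhibition and higher numbers for weaker inhibition), compound 1 gives > 100000 nM, a limit of the assay.
Compound 2 `O=C(/C=C/c1ccc(N2CCCCC2)cc1)c1ccc(I)s1`: in this assay compound 2 gives > 100000 nM, also a limit.
Compound 3 `Cc1ccsc1C1=NNC(c2ccc(N3CCCCC3)cc2)C1`: in this assay compound 3 gives 11000 nM.

Among the compounds with values here, compound 3 holds the only number in the set; the two other entries sit at the limit of > 100000 nM in this assay, at which 2 of the 3 values shown sit. Within the data shown here, the single measured step, a step that the two limits leave unreadable from compound 1 to compound 2, cannot be read because both ends are limits.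

Compound 4 `Clc1cc(C2=NNC(c3ccc(N4CCCCC4)cc3)C2)c(Cl)s1` differs from compound 3 by 2,5-dichlorothiophen-3-yl in place of 3-methylthiophen-2-yl on a carbon with a double bond to nitrogen. Among the measured compounds shown here, no measured step touches this change, and the unreadable step gives no size to lean on. The expectation is therefore a step of no change at the digits printed from compound 3 to compound 4 (within the scatter), no larger than the usual scatter. Compound 4 is estimated at 11000 nM, within 3000 nM to 45000 nM.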

Compound 4, half-maximal inhibitory concentration: 59000 nM
The estimate for compound 4 lay 5.4-fold (0.73 log units) below the measured number; measured number outside the range, above it.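

In this assay the series has its first readable step, a 5.4-fold higher number from compound 3 to compound 4 (0.73 log units; beyond the scatter), so the group on a carbon with a double bond to nitrogen can move this read-out beyond the scatter. The change from 3-methylthiophen-2-yl to 2,5-dichlorothiophen-3-yl swaps the whole group, so this single step cannot be divided among its parts. Compound 1 and compound 2 stand only as limits, and no size can be read from them: the limit of > 100000 nM in this assay, at which 2 of the 4 values shown sit.

From the compounds shown here alone, whether the chlorine atoms alone carry the step remains open. Going by these compounds, how an amine or a carboxylic acid at this place would read also remains open.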